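A few compounds are considered here, and "the series" means these few. Any claim that something is new, unique, unknown or untested is made for them only; others in the source may bear on it.

Measured so far in a physicochemical assay for lipophilicity; on this read-out higher numbers stand for higher lipophilicity and lower numbers for lower lipophilicity:
- compound 1 `CC1(C)CN(c2ccc3c(n2)NC(=O)CO3)[C@H](c2ccccc2)CO1`: 3.3
- compound 2 `N#CC[C@@H]1CN(c2ccc3c(n2)NC(=O)CO3)[C@H](c2ccccc2)CO1`: 2.3

Of these two, compound 2 stands lower at 2.3, and compound 1 gives 3.3, a gap beyond the usual scatter. The two compounds differ in more than one place, so this gap says nothing about any single group.

The next compound to be read is compound 3 `COC[C@@H]1CN(c2ccc3c(n2)NC(=O)CO3)[C@H](c2ccccc2)CO1`, which has no value yet. It carries methoxy in place of cyano on a saturated chain carbon bound to a saturated ring carbon, and the same difference can be read as cyanomethyl to methoxymethyl: methoxy in place of cyano on a saturated chain carbon bound to a saturated ring carbon. Going by the values given here, no measured pair in this small set shows this exchange, so the expectation rests on the exchange itself and on compound 2 at 2.3 as its starting point. The exchange is small as counted, and only a slight rise in this assay is expected, not beyond the scatter. The estimate is a number 0.20 log units higher from compound 2 to compound 3 (within the scatter). For compound 3 the expected value is 2.5, with an estimated range from 2.1 to 2.9.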

Compound 3, distribution coefficient: 2.5
The estimate for compound 3 equals the measured number at the digits printed; measured number inside the range.
By their numbers in this assay, from the lowest: compounds 2 and 3 (each within the scatter of the next); then compound 1.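

In this assay, going by these compounds alone, the exchange of cyano for methoxy on a saturated chain carbon bound to a saturated ring carbon gives a number 0.20 log units higher from compound 2 to compound 3 (within the scatter), the first step in this set that can be read at a single place. At this place, then, the two groups cannot be told apart on this read-out, although the triple bond of the nitrile leaves and an oxygen enters, while the count of heavy atoms and hydrogen-bond acceptors stays the same. Nothing in the data explains why the two groups read so alike.

The shown compounds leave open whether this flat step holds only for this pair or also for other groups at this place, such as an amine, a carboxylic acid or a longer chain like ethoxymethyl. Within the data shown here, they also leave the higher reading of compound 1 at 3.3 unassigned, since compound 1 differs from both compound 2 and compound 3 in more than one place, and no single-place step yet connects it to either of them.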